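The source may report more compounds than this note shows. Statements on the series, on what has been measured and on what is new or still open speak of the compounds shown alone.

Measured so far:
- compound 1 `N=C(N)N/N=C/c1c(-c2cc(Cl)sc2Cl)nc2n1CCS2` gives 11200 nM
- compound 2 `N=C(N)N/N=C/c1c(-c2ccsc2)nc2sccn12` gives 15100 nM

In a functional assay on cells (Cancer cell lines, Homo sapiens) for inhibition (a lower number here means a stronger inhibitor of growth, a higher number a weaker inhibitor of growth), compound 1 gives 11200 nM and so stands level with compound 2, whose 15100 nM lies within the usual scatter of it. Neither number marks out a better compound. The next compound, compound 3 `N=C(N)N/N=C/c1c(-c2ccsc2)nc2n1CCS2`, keeps the core of compound 1 and has thiophen-3-yl in place of 2,5-dichlorothiophen-3-yl on an aromatic carbon, a change counted as thiophen-3-yl in place of 2,5-dichlorothiophen-3-yl on an aromatic carbon in full.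

Among the measured compounds shown here, no measured pair shows this change alone. For the measured compounds named here, the only hint is compound 2, which also carries thiophen-3-yl, on a different core, and gives 15100 nM in this series. A step no larger than the scatter is therefore expected, with a 1.3-fold higher number from compound 1 to compound 3 (0.10 log units; within the scatter) as the estimated size. For compound 3 the estimated value is 14000 nM within an expected range of 7000 nM to 30000 nM overall.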

Compound 3, concentration for 50% growth inhibition: 28800 nM
Compound 3: the middle estimate sits 2.1-fold (0.31 log units) below what was measured, and the stated range covers the measured number.
By their numbers in this assay, from the lowest: compounds 1, 2 and 3 (each within the scatter of the next, the first and the last beyond it).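

Among the compounds shown here, this is the first pair that differs in one place only, and in this assay it puts a measured size on the change at this aromatic carbon: thiophen-3-yl in place of 2,5-dichlorothiophen-3-yl gives a 2.6-fold higher number from compound 1 to compound 3 (0.41 log units; beyond the scatter). On the core of compound 1, then, losing the two chlorine atoms goes with weaker inhibition of growth, a modest but real step. Nothing measured here bears on the reason for this step.

The compounds shown leave open whether a thiophen-3-yl carrying a single chlorine would keep the number of the dichlorinated ring, and whether the same change would give a similar step on the core of compound 2. They also leave open how a different group at this position, such as a phenyl ring or a methyl group, would compare.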